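Ester variation on the shared core in HeLa cytotoxicity

A few compounds are considered here, and "the series" means these few. Any claim that something is new, unique, unknown or untested is made for them only; others in the source may bear on it.

In a functional assay on HeLa cells (Homo sapiens) for cytotoxicity, read by MTT assay, with a stated time of 48 h (a higher number here means a weaker inhibitor, a lower number a stronger inhibitor), compound 3 `CCc1ccc(OC(=O)c2cn(-c3ccccc3)nc2-c2ccncc2)cc1` returns only the limit > 100000 nM. Compound 2 `O=C(NCc1ccccc1)c1cn(-c2ccccc2)nc1-c1ccncc1` likewise returns the limit > 100000 nM. The step that the two limits leave unreadable from compound 2 to compound 3 is consequently not readable in size. Compound 1 `Cc1ccc(C(C)C)c(OC(=O)c2cn(-c3ccccc3)nc2-c2cccnc2)c1` also sits at the limit > 100000 nM. Within the data shown here, no measured step links compound 1 to any other compound, and all three values stand together at the limit of > 100000 nM in this assay, at which 3 of the 3 values shown sit. Compound 4 `Cc1ccc(C(C)C)c(OC(=O)c2cn(-c3ccccc3)nc2-c2ccncc2)c1` differs from compound 3 by 2-isopropyl-5-methylphenyl in place of 4-ethylphenyl on an oxygen next to a carbonyl group. Among the measured compounds shown here, no measured step bears on this change, and every value so far is a limit rather than a number. The step that the limit leaves unreadable from compound 3 to compound 4 is expected to remain unreadable, with compound 4 again reaching the limit. Compound 4 is estimated at 150000 nM, within 40000 nM to 600000 nM.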

Compound 4, half-maximal inhibitory concentration: > 100000 nM
Compound 4: no number, only a limit; the forecaster's own chance of this, stated with the estimate: 85%; the middle value is on the limit's open side.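

The steps from compound 3 and compound 1 to compound 4 cannot be read, as each compound gives only a limit: the limit of > 100000 nM in this assay, at which 4 of the 4 values shown sit.

The compounds shown leave open which change on the shared core, if any, would give a number in this assay.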